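A few compounds are considered here, and "the series" means these few. Any claim that something is new, unique, unknown or untested is made for them only; others in the source may bear on it.

Of the compounds shown here, three built on a shared core have been measured in a functional assay on NCI-H226 cells (Homo sapiens) for inhibition, read by MTT assay, with a stated time of 48 h, tested at 10 uM; a lower number here means less inhibition, a higher number more inhibition at the concentration tested (going by the name of the read-out). Compound 1 `COc1cc(NC(=O)Nc2cc(Nc3cccc(C(C)(C)C)c3)ncn2)cc(OC)c1` gives 40%. Compound 2 `COc1cc(NC(=O)Nc2cc(Nc3ccc(C)c(F)c3)ncn2)cc(OC)c1` gives 39.7%, and compound 3 `COc1cc(NC(=O)Nc2cc(Nc3cc(Br)ccc3OC)ncn2)cc(OC)c1` gives 42.7%. The step of a number 2.7 percentage points higher from compound 1 to compound 3 (within the scatter) and the step of a number 3 percentage points higher from compound 2 to compound 3 (within the scatter) both lie within the scatter, as does the step of a number 0.3 percentage points lower from compound 1 to compound 2 (within the scatter), so compound 3 stands level with the other two on these numbers rather than apart from them.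

Compound 4 `COc1cc(NC(=O)Nc2cc(Nc3ccc(OC)c(C)c3)ncn2)cc(OC)c1` has not yet been measured. It differs from compound 3 in one place: 4-methoxy-3-methylphenyl in place of 5-bromo-2-methoxyphenyl on a nitrogen on an aromatic ring. The measured steps that bear on this change are the two that exchange the group on the same nitrogen on an aromatic ring, a number 2.7 percentage points higher from compound 1 to compound 3 (within the scatter) and a number 3 percentage points higher from compound 2 to compound 3 (within the scatter), and neither moved the number beyond the scatter. No step beyond the scatter is therefore expected in this assay from compound 3 to compound 4, and the expected step is a number 1.7 percentage points lower from compound 3 to compound 4 (within the scatter). Compound 4 is estimated to give 41%, with a range from 28% to 54%.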

Compound 4, a percentage reported as inhibition, at one concentration (the size of the read-out at that concentration, not a potency): 39.7%
Estimate against measurement, compound 4: 1.3 percentage points above; measured number inside the range.
By their numbers in this assay, from the lowest: compounds 2, 4, 1 and 3 (each within the scatter of the next).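

With 4-methoxy-3-methylphenyl on the nitrogen on an aromatic ring, this assay gives a number 3 percentage points lower from compound 3 to compound 4 (within the scatter) and no change at the digits printed from compound 2 to compound 4 (within the scatter) and also a number 0.3 percentage points lower from compound 1 to compound 4 (within the scatter) here. The series at this position now includes a group that carries methoxy and methyl with neither a halogen nor a tert-butyl group, and it stands level with the three earlier groups, so the bromine of compound 3 shows no separate mark on the number in these compounds. Nothing at hand explains why these four groups read alike.

As far as these compounds go, all four groups at this position are substituted phenyl rings, so it remains open whether a phenyl ring carrying a carboxylic acid or a dimethylamino group would step beyond the scatter. From the compounds shown here alone, whether these compounds would also stand level at another concentration or in other cells also remains open.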